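Furan-3-yl for thiophen-3-yl on the shared core

A few compounds are considered here, and "the series" means these few. Any claim that something is new, unique, unknown or untested is made for them only; others in the source may bear on it.

Compound 1 `O=c1[nH]cnc2c1c(-c1ccsc1)cn2[C@@H]1O[C@H](CO)[C@@H](O)[C@H]1O` carries thiophen-3-yl on the shared core. In a functional assay on K562 cells (Homo sapiens), read by MTT assay, with a stated time of 72 h (on this read-out lower numbers stand for stronger inhibition and higher numbers for weaker inhibition), compound 1 gives only a limit, > 20000 nM, and no number. Among the three values shown, compound 1 therefore sits at the limit of > 20000 nM in this assay, at which 1 of the 3 values shown sits. For the measured compounds named here, two further compounds differ from compound 1 in more than one place, so no single step leads to them: compound 2 `Cc1nc(N)c2c(-c3cc4ccccc4o3)cn([C@@H]3O[C@H](CO)[C@@H](O)[C@H]3O)c2n1` gives 4990 nM in this assay, and compound 3 `COc1ncnc2c1c(-c1cc3ccccc3o1)cn2[C@@H]1O[C@H](CO)[C@@H](O)[C@H]1O` gives 13100 nM in this assay. Going by the values given here, what these two show is only that their own values come out as numbers rather than as a limit.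

Compound 4 `O=c1[nH]cnc2c1c(-c1ccoc1)cn2[C@@H]1O[C@H](CO)[C@@H](O)[C@H]1O` is not yet measured. It differs from compound 1 by furan-3-yl in place of thiophen-3-yl on an aromatic carbon. Among the compounds with values here, no measured pair separates these two groups on this core, so the data give no direction for the change. Expected is a step that the limit leaves unreadable from compound 1 to compound 4, nothing beyond the scatter. Compound 4 is thus estimated to give about 30000 nM in this assay, within a range of 10000 nM to 100000 nM, and most likely again only a limit.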

Compound 4, half-maximal inhibitory concentration: 14500 nM
Estimate against measurement, compound 4: 2.1-fold (0.32 log units) above; the measured number falls inside the stated range.
By their numbers in this assay, from the lowest: compound 2; then compounds 3 and 4 (each within the scatter of the next). At a limit, above all of these: compound 1.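

On the shared core, furan-3-yl on this aromatic carbon gives a number in this assay, where thiophen-3-yl gave none, so this position now has one reading that is a value and not a limit. The change reads as an at least 1.3-fold lower number from compound 1 to compound 4 (0.13 log units; that floor lies within the scatter), so only a floor can be stated for its size, and that floor does not separate the two groups. Compound 1 remains the only compound at a limit: the limit of > 20000 nM in this assay, at which 1 of the 4 values shown sits.

Still open, on these data alone, is whether a number for compound 1 would differ from compound 4 by more than the scatter, and how this position responds to a group other than these two, such as an amine or a phenyl ring. Compound 2 and compound 3 differ from compound 4 in more than one place, so they add nothing on this change.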